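A few compounds are considered here, and "the series" means these few. Any claim that something is new, unique, unknown or untested is made for them only; others in the source may bear on it.

In a functional assay on SW-620 cells (Homo sapiens) for inhibition, read by sulforhodamine B assay, with a stated time of 48 h (on this read-out lower numbers stand for stronger inhibition of growth and higher numbers for weaker inhibition of growth), three compounds that share one core have been measured. Compound 1 `COc1cc(C)cc(-c2nn(CC#N)cc2-c2ccc(-c3cccc(C(C)=O)c3)nc2)c1` gives 19300 nM. Compound 2 `Cc1cc(O)cc(-c2nn(CC#N)cc2-c2ccnc(-c3ccc(Oc4ccccc4)cc3)c2)c1` gives 4330 nM. Compound 3 `COc1cc(C)cc(-c2nn(CC#N)cc2-c2ccnc(-c3ccc(N(C)C)cc3)c2)c1` reaches only > 100000 nM, which is a limit of this assay rather than a number. Compound 3 thus sits at the limit of > 100000 nM in this assay, at which 1 of the 3 values shown sits, and its numbers place it weaker than compound 1 and compound 2 as far as a limit allows a comparison.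

Compound 4 `Cc1cc(O)cc(-c2nn(CC#N)cc2-c2ccnc(-c3ccc(N(C)C)cc3)c2)c1` differs from compound 3 by hydrogen in place of methyl on an oxygen on an aromatic ring. Within the data shown here, no measured pair shows this change on its own. Compound 2, which carries the hydroxy, and compound 1, which carries the methoxy, also differ from each other elsewhere, so their two values show only that both fall within the measured range while compound 3 does not. The change from compound 3 to compound 4 is therefore expected to bring a modest gain, an at least 2.5-fold lower number from compound 3 to compound 4 (0.39 log units; beyond the scatter), with a real chance that this assay again reports only a limit. The estimate for compound 4 is 40000 nM, expected to lie between 8000 nM and 150000 nM.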

Compound 4, concentration for total growth inhibition: 17500 nM
Beside the measured number, compound 4's estimate is 2.3-fold (0.36 log units) above it; the range from low to high includes it.
By their numbers in this assay, from the lowest: compound 2; then compounds 4 and 1 (each within the scatter of the next). At a limit, above all of these: compound 3.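

In this assay, among these compounds, the change from methoxy to hydroxy on an otherwise unchanged compound can now be read on its own for the first time, and it gives an at least 5.7-fold lower number from compound 3 to compound 4 (0.75 log units; beyond the scatter). As far as these compounds go, the true size of this step remains unknown because compound 3 stands at a limit of the assay: the limit of > 100000 nM in this assay, at which 1 of the 4 values shown sits. With the hydroxy kept in place, the other single change now readable, dimethylamino in place of phenoxy on an aromatic carbon, gives a 4.0-fold higher number from compound 2 to compound 4 (0.61 log units; beyond the scatter), so the group at that second place also matters.

From the compounds shown here alone, whether methoxy to hydroxy gives a step of similar size with phenoxy in place of the dimethylamino remains open. Also open, going by these compounds, is how this assay would read an ethoxy or an amine in place of the hydroxy.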